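Hydrazone aryl variation on the shared core

This account rests on a few compounds, and the source may have more. Where it says the series, first, only, none or still open, it means among the compounds named here.

Measured compounds:
compound 1 `Cn1c(=O)c(=O)n(C2CCCC2)c2nc(N/N=C/c3cccs3)ncc21`, 75600 nM
compound 2 `Cn1c(=O)c(=O)n(C2CCCC2)c2nc(N/N=C/c3ccc(F)cc3Cl)ncc21`, 15200 nM

For the measured compounds named here, in a functional assay on PC-3 cells (Homo sapiens) for antiproliferative activity, read by MTT assay (on this read-out lower numbers stand for stronger inhibition and higher numbers for weaker inhibition), compound 2 gives the lowest of the two numbers so far; its nearest neighbour is compound 1, and the step of a 5.0-fold lower number from compound 1 to compound 2 (0.70 log units; beyond the scatter) lies beyond the scatter.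

Compound 3 `COc1ccc(/C=N/Nc2ncc3c(n2)n(C2CCCC2)c(=O)c(=O)n3C)cc1` is the next candidate. It differs from compound 2 by 4-methoxyphenyl in place of 2-chloro-4-fluorophenyl on a carbon with a double bond to nitrogen.

Going by the values given here, only one measured step touches this position, the one from compound 1 to compound 2, where a thiophen-2-yl gave way to the 2-chloro-4-fluorophenyl and the number fell by a 5.0-fold lower number from compound 1 to compound 2 (0.70 log units; beyond the scatter). That step exchanged a five-membered group for a six-membered one; the present change keeps the six-membered aromatic ring of carbon only and exchanges the chlorine and fluorine for a methoxy group with one hydrogen-bond acceptor. Among the compounds with values here, no measured step covers such an exchange, so the direction cannot be read from the series, and the expected change in this assay is a modest rise in the number, possibly within the scatter.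

Compound 3 is therefore expected to give about 30000 nM in this assay, with a range of 8000 nM to 100000 nM, which corresponds to an estimated step of a 2.0-fold higher number from compound 2 to compound 3 (0.30 log units; within the scatter).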

Compound 3, half-maximal inhibitory concentration: 26300 nM
Compound 3: the middle estimate sits 1.1-fold (0.06 log units) above what was measured; the range from low to high includes it.
By their numbers in this assay, from the lowest: compounds 2 and 3 (each within the scatter of the next); then compound 1.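

In this assay the exchange of 2-chloro-4-fluorophenyl for 4-methoxyphenyl on a carbon with a double bond to nitrogen gives a 1.7-fold higher number from compound 2 to compound 3 (0.24 log units; within the scatter) and so does not separate these two groups, although they share no substituent on the six-membered aromatic ring. Set against thiophen-2-yl, the 4-methoxyphenyl gives a 2.9-fold lower number from compound 1 to compound 3 (0.46 log units; beyond the scatter) as a second step beyond the scatter, so the lower number seen in a 5.0-fold lower number from compound 1 to compound 2 (0.70 log units; beyond the scatter) does not require the chlorine and fluorine of compound 2, and both compounds with a six-membered aromatic ring here stand on the same side of compound 1. Nothing available explains either step or bears on this position.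

Still open, on these data alone, is whether an amine, a carboxylic acid or a longer chain such as butoxy on the six-membered aromatic ring would move the number beyond the scatter from compound 2 and compound 3. Also open, as far as these compounds go, is whether a ring carrying only chlorine or only fluorine would stand with these two compounds or nearer to compound 1.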